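From ethoxy to (oxolan-2-yl)methoxy on compound 3

A few compounds are considered here, and "the series" means these few. Any claim that something is new, unique, unknown or untested is made for them only; others in the source may bear on it.

Among the compounds with values here, in a functional assay (aorta) with Oryctolagus cuniculus as the target (on this read-out higher numbers stand for weaker inhibition and lower numbers for stronger inhibition), compound 3 `CCO/C(O)=C1\C(C)=NC(C)=C(C(=O)OCCCN2C(=O)c3ccccc3S2(=O)=O)C1c1ccccc1C(F)(F)F` gives 0.8 nM, the lowest of the three numbers so far. Compound 4 `CC1=NC(C)=C(C(=O)OCCCN2C(=O)c3ccccc3S2(=O)=O)C(c2ccccc2C(F)(F)F)/C1=C(\O)OCC1CCCO1` carries oxolan-2-yl in place of methyl on a saturated chain carbon bound to an oxygen on an unsaturated carbon. Within the data shown here, the one measured step, a 2.4-fold lower number from compound 1 to compound 3 (0.38 log units; beyond the scatter), is modest and concerns the phenyl substituent, not this place. Compound 2 `CC1=NC(C)=C(C(=O)OCCCN2C(=O)c3ccccc3S2(=O)=O)C(c2ccccc2[N+](=O)[O-])/C1=C(\O)OCC1CCCO1`, with the same (oxolan-2-yl)methoxy group, gives 6.8 nM, a higher number than compound 1 `CCO/C(O)=C1\C(C)=NC(C)=C(C(=O)OCCCN2C(=O)c3ccccc3S2(=O)=O)C1c1cccc([N+](=O)[O-])c1` at 1.9 nM. Among the measured compounds shown here, those two also differ in the phenyl substituent, so no measured step isolates the change. A higher number in this assay is therefore expected, with an estimated step of a 3.1-fold higher number from compound 3 to compound 4 (0.49 log units; beyond the scatter). For compound 4 the estimate is 2.5 nM, within 0.7 nM to 9 nM.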

Compound 4, half-maximal inhibitory concentration: 3.7 nM
For compound 4 the middle estimate is 1.5-fold (0.17 log units) below the measured one; the measured number falls inside the stated range.
By their numbers in this assay, from the lowest: compound 3; then compounds 1, 4 and 2 (each within the scatter of the next, the first and the last beyond it).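

In this assay the change from ethoxy to (oxolan-2-yl)methoxy now has its own reading (a 4.6-fold higher number from compound 3 to compound 4 (0.67 log units; beyond the scatter)), which is beyond the scatter. With (oxolan-2-yl)methoxy held fixed, trifluoromethyl in place of nitro gives a step within the scatter (a 1.8-fold lower number from compound 2 to compound 4 (0.26 log units; within the scatter)). No supporting measurement accounts for either step.

Still open, from the compounds shown here alone, is how methoxy or 2-methoxyethoxy reads at this place. The compounds shown also leave open whether the ethoxy to (oxolan-2-yl)methoxy step holds with 3-nitrophenyl on the core.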